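The compounds below may be only part of what the source reports. "The series", "measured", "known", "first", "only" and "open" are said of these compounds alone.

Compound 3, `Cc1nc2c(OCc3ccccc3)cccn2c1/N=C/N(C)C`, stands highest of the three numbers in a functional assay on the whole organism with Rattus norvegicus as the target, at a dose of 40 mg/kg by the intraperitoneal route (a higher number here means more inhibition at the dose given (going by the name of the read-out), a lower number less inhibition), giving 64%. Compound 1, `Cc1nc2c(OCc3ccccc3)cccn2c1CN`, gives 46%, and compound 2, `Cc1nc2c(OCc3ccccc3)cccn2c1NC=O`, gives 49%. The move to compound 4, `CNc1c(C)nc2c(OCc3ccccc3)cccn12`, is a group of 2 heavy atoms (1 carbon, 1 nitrogen; no ring) in place of a group of 5 heavy atoms (3 carbon, 2 nitrogen; no ring), on an aromatic carbon. Within the data shown here, two measured steps bear on this: a number 18 percentage points higher from compound 1 to compound 3 (beyond the scatter) and a number 15 percentage points higher from compound 2 to compound 3 (beyond the scatter), both running toward the larger group. The change to compound 4 runs the other way, back to a small group, so a modest drop beyond the scatter is expected; the two small groups already measured differed little from each other (a number 3 percentage points higher from compound 1 to compound 2 (within the scatter)), which leaves the exact size uncertain. Compound 4 is therefore expected to give about 48%, between 35% and 62%, a step of a number 16 percentage points lower from compound 3 to compound 4 (beyond the scatter).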

Compound 4, a percentage reported as inhibition, in the whole organism at one dose (the size of the read-out at that dose, not a potency): 55%
Estimate against measurement, compound 4: 7 percentage points below; the range from low to high includes it.
By their numbers in this assay, from the lowest: compounds 1, 2, 4 and 3 (each within the scatter of the next, the first and the last beyond it).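

With methylamino on this aromatic carbon, all three steps stay within the scatter: a number 9 percentage points lower from compound 3 to compound 4 (within the scatter) and a number 6 percentage points higher from compound 2 to compound 4 (within the scatter) and also a number 9 percentage points higher from compound 1 to compound 4 (within the scatter). Compound 4 therefore cannot be separated from either side, so the clear gap between compound 3 and compounds 1 and 2 no longer reads as a simple split between large and small groups. Nothing available explains these numbers. Still open, as far as these compounds go, is how a plain amine, dimethylamino or ethylamino at this carbon would fare in this assay. Whether these closely spaced numbers would separate at another dose is also unknown.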